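Swapping Fluoro for Methoxy: An Estimate of Lipophilicity

A few compounds are considered here, and "the series" means these few. Any claim that something is new, unique, unknown or untested is made for them only; others in the source may bear on it.

Of the compounds shown here, two have been measured in a physicochemical assay for lipophilicity; a higher number here means a more lipophilic compound, a lower number a more polar compound. Compound 1 `Cc1ccc(/C=C2\CCC/C(=C\c3ccccc3[N+](=O)[O-])C2=O)cc1` gives 4.86. Compound 2 `O=C1/C(=C/c2ccc(F)cc2)CCC/C1=C\c1ccc([N+](=O)[O-])cc1` gives 5.08, a number so close to that of compound 1 that the two lie within the scatter of the measurement and cannot be told apart on these numbers. For the measured compounds named here, no pair of measured compounds differs in only one place, so no measured step is available as a guide for what follows.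

Compound 3 `COc1ccc(/C=C2\CCC/C(=C\c3ccc([N+](=O)[O-])cc3)C2=O)cc1` differs from compound 2 in one place: methoxy in place of fluoro on an aromatic carbon. The step from compound 2 to compound 3 in this assay is expected to be small, a slight move toward a lower number that stays within the scatter, a number 0.13 log units lower from compound 2 to compound 3 (within the scatter). Compound 3 is therefore estimated at 4.95, with a range from 4.6 to 5.3.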

Compound 3, partition coefficient: 5.08
For compound 3 the middle estimate is 0.13 log units below the measured one; measured number inside the range.
By their numbers in this assay, from the lowest: compounds 1, 2 and 3 (each within the scatter of the next).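

For the compounds shown here, the swap of fluoro for methoxy on this aromatic carbon, para to a large group, gives the first step that can be read in one place: in this assay the change is no change at the digits printed from compound 2 to compound 3 (within the scatter). Methoxy brings a hydrogen-bond acceptor that fluoro lacks, yet this one pair shows the number staying put at this position, which the earlier compounds, differing in more than one place, could not show. The data offer no measured explanation for this outcome.

Still open, as far as these compounds go, is whether an amine, a carboxylic acid or a longer chain such as ethoxy on the same aromatic carbon would also leave the number in place. From the compounds shown here alone, whether the swap from 4-fluorophenyl to 4-methoxyphenyl would give the same step with the rest of the molecule changed also stays open.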